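The compounds below may be only part of what the source reports. "The series", "measured", "known", "first", "only" and "open" are said of these compounds alone.

Working notes on the sulfonamide series in a functional assay on HPAC cells (Homo sapiens) for inhibition, read by MTT assay, with a stated time of 72 h; on this read-out lower numbers stand for stronger inhibition of growth and higher numbers for weaker inhibition of growth. All three measured compounds carry the same core and differ only in the benzyl group on the amine nitrogen. In this assay compound 1 `O=S(=O)(NCCCNCc1ccc(Cl)c(Cl)c1)c1cc(C(F)(F)F)cc(C(F)(F)F)c1` gives 2500 nM, compound 2 `O=S(=O)(NCCCNCc1ccccc1)c1cc(C(F)(F)F)cc(C(F)(F)F)c1` gives 3200 nM and compound 3 `O=S(=O)(NCCCNCc1ccc(Br)cc1)c1cc(C(F)(F)F)cc(C(F)(F)F)c1` gives 2900 nM. The three exchanges on the benzyl ring move the numbers little: a 1.3-fold higher number from compound 1 to compound 2 (0.11 log units; within the scatter), a 1.2-fold higher number from compound 1 to compound 3 (0.06 log units; within the scatter) and a 1.1-fold lower number from compound 2 to compound 3 (0.04 log units; within the scatter). Of the three numbers compound 3 is the second highest, with compound 2 nearest and compound 1 furthest, both separations inside the scatter.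

Compound 4 `COc1ccc(CNCCCNS(=O)(=O)c2cc(C(F)(F)F)cc(C(F)(F)F)c2)cc1` is the next point: methoxy in place of bromo on an aromatic carbon. Within the data shown here, the closest precedent is the only other change at the same aromatic carbon, a 1.1-fold lower number from compound 2 to compound 3 (0.04 log units; within the scatter), which did not move the read-out beyond the scatter; the other two benzyl exchanges behaved alike. Among the measured compounds shown here, nothing among the measured compounds suggests that a substituent at this carbon of the benzyl ring shifts growth inhibition, so the expected step is a 1.0-fold higher number from compound 3 to compound 4 (0.01 log units; within the scatter), that is, none beyond the scatter. Compound 4 is therefore estimated at 3000 nM in this assay, with a range from 1500 nM to 6000 nM.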

Compound 4, concentration for 50% growth inhibition: 3000 nM
The estimate for compound 4 equals the measured number at the digits printed; measured number inside the range.
By their numbers in this assay, from the lowest: compounds 1, 3, 4 and 2 (each within the scatter of the next).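

In this assay, methoxy in place of bromo on the aromatic carbon para to a large group gives a 1.0-fold higher number from compound 3 to compound 4 (0.01 log units; within the scatter), so a group counted with a hydrogen-bond acceptor, where bromo has none, leaves the read-out within the scatter. The other two new exchanges agree, with methoxy in place of hydrogen at that carbon giving a 1.1-fold lower number from compound 2 to compound 4 (0.03 log units; within the scatter) and 4-methoxyphenyl in place of 3,4-dichlorophenyl giving a 1.2-fold higher number from compound 1 to compound 4 (0.08 log units; within the scatter), so every step among the four compounds now lies within the scatter and none goes against this flat picture. No measurement at hand bears on why the benzyl ring tolerates these exchanges.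

On these data alone, whether the same flat response holds for a carboxylic acid or an amine at this aromatic carbon remains open. Also open, as far as these compounds go, is how the read-out responds outside the benzyl group, for example to a longer chain linking the sulfonamide to the amine, or to a nitrile in place of a trifluoromethyl group on the shared core.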